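The source may hold more compounds than are shown below. What is called first, only, known or untested is meant among the compounds shown, and "the series" means these compounds.

Measured so far:
compound 1 `COc1ccc(F)cc1CNCCCNc1ccnc2cc(Cc3ccc(F)cc3Cl)ccc12`, 9.47
compound 2 `COc1cccc(CNCCCNc2ccnc3cc(Cc4cccc(C(F)(F)F)c4)ccc23)c1O`, 9.47

Both numbers come from a physicochemical assay for acid dissociation. In this assay compound 1 gives 9.47 and compound 2 gives 9.47, so compound 1 stands level with compound 2 at the digits shown, within the usual scatter of such measurements. Compound 3 `COc1ccc(F)cc1CNCCCNc1ccnc2cc(Oc3ccccc3)ccc12` has not yet been measured. It differs from compound 1 in one place: phenoxy in place of 2-chloro-4-fluorobenzyl on an aromatic carbon. Among the measured compounds shown here, no step between measured compounds exists for a change of this kind, so the expectation rests on what the two measured compounds show. Compound 1 and compound 2 differ from each other in structure yet give readings that cannot be told apart, and on that basis the step from compound 1 to compound 3 is expected to be no larger than the scatter, a number 0.02 log units lower from compound 1 to compound 3 (within the scatter). For compound 3 the estimate in this assay is 9.45, with a range from 9.15 to 9.75.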

Compound 3, acid dissociation constant: 9.28
Compound 3: middle estimate off by 0.17 log units, on the high side; low and high end bracket the measured number.
By their numbers in this assay, from the lowest: compounds 3, 1 and 2 (each within the scatter of the next).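

Among the compounds shown here, this is the first comparison in which only this position differs: in this assay placing phenoxy in place of 2-chloro-4-fluorobenzyl on the aromatic carbon gives a number 0.19 log units lower from compound 1 to compound 3 (within the scatter) and so shows that this particular exchange does not take the reading beyond the usual scatter. That holds even though the entering group carries one hydrogen-bond acceptor, has no chlorine or fluorine, and has fewer heavy atoms than the group it replaces. Nothing measured here bears on why the step has this size.

Going by these compounds, whether a group of a different kind on this same aromatic carbon, such as an amine or a carboxylic acid, would give a step beyond the scatter remains open. The same question stands for a longer chain at this position.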